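The compounds below may be only part of what the source reports. "The series", "measured", "known", "first", "only" and "open" are said of these compounds alone.

Of the compounds shown here, three sharing one core have so far been tested in a functional assay on HepG2 cells (Homo sapiens) for inhibition, read by MTT assay, with a stated time of 72 h; a higher number here means a weaker inhibitor, a lower number a stronger inhibitor. Compound 1, `C#CCSc1nc(NCCC(C)C)c2ccncc2n1`, carries an isopentyl group on a nitrogen on an aromatic ring. In this assay compound 1 gives only > 80000 nM, which is a limit of the measurement rather than a number. Compound 2, `C#CCSc1nc(Nc2ccc(F)cc2)c2ccncc2n1`, carries a 4-fluorophenyl in that place and gives 10800 nM in this assay. Compound 3, `C#CCSc1nc(Nc2ccc(Br)cc2)c2ccncc2n1`, carries a 4-bromophenyl there and gives 56200 nM in this assay. The step of an at least 7.4-fold lower number from compound 1 to compound 2 (0.86 log units; beyond the scatter) lies beyond the scatter, while for an at least 1.4-fold lower number from compound 1 to compound 3 (0.15 log units; that floor lies within the scatter) the floor cannot be told from scatter. Between the two aryl compounds, a 5.2-fold higher number from compound 2 to compound 3 (0.72 log units; beyond the scatter).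

Compound 4, `C#CCSc1nc(Nc2ccccc2O)c2ccncc2n1`, has not yet been measured. It differs from compound 1 by 2-hydroxyphenyl in place of isopentyl on a nitrogen on an aromatic ring. Among the measured compounds shown here, the steps that bear on it are the two in which an aryl group took the place of the isopentyl: one gave an at least modest drop, the other gave a floor that scatter could hide. A substituted phenyl in this place has therefore, in the two cases seen, not raised the number, and a drop of roughly the size seen with compound 2 seems plausible but uncertain. For compound 4 the expected step is an at least 2.6-fold lower number from compound 1 to compound 4 (0.42 log units; beyond the scatter). Compound 4 is estimated at 30000 nM, within a range from 9000 nM to 90000 nM.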

Compound 4, half-maximal inhibitory concentration: > 80000 nM
Compound 4 gave a limit, no number; the forecaster's own chance of this, stated with the estimate: 25%; at least 2.6-fold (0.42 log units) between middle value and limit.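

In this assay, the change to 2-hydroxyphenyl gives an at least 7.4-fold higher number from compound 2 to compound 4 (0.86 log units; beyond the scatter), so the earlier impression that a substituted phenyl on this nitrogen keeps the number down does not hold for every such group. Set against the other aryl compound, the change gives an at least 1.4-fold higher number from compound 3 to compound 4 (0.15 log units; that floor lies within the scatter), and that floor cannot be told from scatter, so compound 4 can be placed clearly behind compound 2 but not behind compound 3. Compound 1 and compound 4 both end at a limit, so the step between them cannot be read and the aryl swap at this position has no measurable size here: the limit of > 80000 nM in this assay, at which 2 of the 4 values shown sit.

As far as these compounds go, how far the true value of compound 4 lies past its limit remains unknown, and so does whether the hydroxy group itself sets this result or some other feature of the 2-hydroxyphenyl does. An unsubstituted phenyl, a methoxyphenyl or a benzyl on this nitrogen would bear on that question, while a shorter chain such as propyl would show whether any alkyl group can give a readable number.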